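Swapping a sulfone for a thioether on a chloro core

The source may hold more compounds than are shown below. What is called first, only, known or untested is meant among the compounds shown, and "the series" means these compounds.

Of the compounds shown here, three have been measured so far in an assay for binding affinity to Alpha-1D adrenergic receptor (Homo sapiens), read by radioligand binding; a higher number here means a weaker inhibitor, a lower number a stronger inhibitor. Compound 2 `Cc1ccc(S(C)(=O)=O)c(NCC2=NCCN2)c1` gives 4790 nM, compound 3 `CS(=O)(=O)c1ccc(Cl)cc1NCC1=NCCN1` gives 2400 nM, and compound 1 `CSc1ccc(C)cc1NCC1=NCCN1` gives 17.4 nM.

Two single changes connect these. The core of compound 3 differs from the core of compound 2 by chloro in place of methyl on an aromatic carbon. This gave a 2.0-fold lower number from compound 2 to compound 3 (0.30 log units; within the scatter). Compound 1 differs from compound 2 by methylsulfanyl in place of methylsulfonyl on an aromatic carbon, and that gave a 280-fold lower number from compound 2 to compound 1 (2.44 log units; beyond the scatter).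

Compound 4 `CSc1ccc(Cl)cc1NCC1=NCCN1` has not yet been measured in this assay. It differs from compound 3 by methylsulfanyl in place of methylsulfonyl on an aromatic carbon. Among the compounds with values here, this is the same kind of change as the one from compound 2 to compound 1, not the same one: in compound 1 the entering group sits para to a methyl group (1 heavy atom), whereas in compound 4 it sits para to a chloro group (1 heavy atom). The chloro and methyl cores appear to behave alike, because the swap between them gave only a 2.0-fold lower number from compound 2 to compound 3 (0.30 log units; within the scatter).

Compound 4 is therefore expected to show a step of a 270-fold lower number from compound 3 to compound 4 (2.43 log units; beyond the scatter), about as large as the earlier one. On that basis compound 4 is estimated at 9 nM in this assay, with a plausible range from 2 nM to 40 nM.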

Compound 4, inhibition constant: 4.68 nM
Beside the measured number, compound 4's estimate is 1.9-fold (0.28 log units) above it, and the stated range covers the measured number.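

In this assay, putting methylsulfanyl in place of methylsulfonyl gave a 510-fold lower number from compound 3 to compound 4 (2.71 log units; beyond the scatter), so the large gain seen with the methyl group also appears with the chloro group, and the two steps agree in size: the same change on two cores in this assay, a 280-fold lower number (2.44 log units; beyond the scatter) from compound 2 to compound 1 and a 510-fold lower number (2.71 log units; beyond the scatter) from compound 3 to compound 4, 1.9-fold (0.27 log units) apart, within the scatter of two such steps. The other change can be read across as well, since chloro in place of methyl gave a 3.7-fold lower number from compound 1 to compound 4 (0.57 log units; beyond the scatter), a modest step that still matches its counterpart in the sulfone pair: the same change on two cores in this assay, a 2.0-fold lower number (0.30 log units; within the scatter) from compound 2 to compound 3 and a 3.7-fold lower number (0.57 log units; beyond the scatter) from compound 1 to compound 4, 1.9-fold (0.27 log units) apart, within the scatter of two such steps. Together these steps show that, among these four compounds, each change keeps much the same size when the other place is altered, but two cores are too few to support a general rule, and the numbers do not explain why the methylsulfanyl compounds give so much lower a number.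

Still open, as far as these compounds go, is how other groups would behave in the place held by methylsulfanyl, such as methoxy or a longer chain like ethylsulfanyl, and whether the large step would hold up against them. From the compounds shown here alone, it is also open whether the step would keep its size with a group other than methyl or chloro in the second place, such as bromo or a plain hydrogen.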